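The source may hold more compounds than are shown below. What is called first, only, known or untested is meant among the compounds shown, and "the series" means these compounds.

Series notes. In a functional assay on MCF7 cells (Homo sapiens) for inhibition, read by sulforhodamine B assay, with a stated time of 48 h (on this read-out lower numbers stand for stronger inhibition of growth and higher numbers for weaker inhibition of growth), compound 1 `COc1cc(-c2nn(-c3cccc(NC(=O)c4cccc(C(F)(F)F)c4)c3)cc2-c2ccncc2)ccc1Cl` gives > 50000 nM, which is a limit of the assay and not a number (the limit of > 50000 nM in this assay, at which 1 of the 3 values shown sits). Compound 3 `O=C(Nc1cccc(-n2cc(-c3ccncc3)c(-c3ccc(Cl)c(O)c3)n2)c1)Nc1ccc(Cl)c(C(F)(F)F)c1` also gives only a limit, > 32500 nM (the limit of > 32500 nM in this assay, at which 1 of the 3 values shown sits). Compound 2 `O=C(Nc1cccc(-n2cc(-c3ccncc3)c(-c3ccc(Cl)c(O)c3)n2)c1)Nc1cc(C(F)(F)F)cc(C(F)(F)F)c1` gives 5790 nM in this assay. Compound 1 therefore cannot be placed against the others beyond its limit. Compound 4 `COc1cc(-c2nn(-c3cccc(NC(=O)Nc4ccc(Cl)c(Cl)c4)c3)cc2-c2ccncc2)ccc1Cl` differs from compound 1 by (3,4-dichlorophenyl)amino in place of 3-(trifluoromethyl)phenyl on a carbonyl carbon, that is, (3,4-dichlorophenyl)carbamoyl in place of (3-(trifluoromethyl)phenyl)carbonyl. Within the data shown here, no measured pair in this assay isolates that change; compound 2 and compound 3 carry a different core. The expected change in this assay is estimated as an at least 2.0-fold lower number from compound 1 to compound 4 (0.30 log units; that floor lies within the scatter), a modest step toward lower numbers that starts from a limit. Compound 4 is expected to give 25000 nM, within 7000 nM to 60000 nM.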

Compound 4, concentration for total growth inhibition: > 50000 nM
Compound 4 was reported as a limit (the forecaster's own chance of this, stated with the estimate: 50%); middle value at least 2.0-fold (0.30 log units) from the limit.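

Compound 4 gives > 50000 nM in this assay, a limit of the assay and not a number. Compound 1 gives > 50000 nM, also a limit. Among these compounds, no step between compound 1 and compound 4 can be read. From the compounds shown here alone, whether (3,4-dichlorophenyl)amino in place of 3-(trifluoromethyl)phenyl on a carbonyl carbon shifts the read-out at all remains open.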